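Cyano to bromo in compound 1: working notes

This account rests on a few compounds, and the source may have more. Where it says the series, first, only, none or still open, it means among the compounds named here.

Going by the values given here, in a functional assay on SK-N-SH cells (Homo sapiens) for inhibition, read by MTT assay, with a stated time of 72 h, tested at 50 uM (a lower number here means less inhibition of growth, a higher number more inhibition of growth at the concentration tested), compound 1 `C=CCc1ccc(OCc2cn(-c3ccc(C#N)cc3)nn2)c(O)c1` gives 62.5% and stands as the higher of the two numbers so far. Compound 2 `C=CCc1cc(O)c(O)c(CN2CCC(CO)CC2)c1` gives 49.4% in the same read-out, lower than compound 1 by more than the usual scatter. Among the compounds with values here, no measured pair differs in one place only, so the data hold no direct step to scale from, and the gap between these two compounds says nothing about the substituent in question here.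

Compound 3 `C=CCc1ccc(OCc2cn(-c3ccc(Br)cc3)nn2)c(O)c1` remains unmeasured. It carries bromo in place of cyano on an aromatic carbon, para to a large group bromo in place of cyano on an aromatic carbon and the same difference reads as 4-cyanophenyl to 4-bromophenyl. The rest of the structure of compound 1 stays unchanged, so the expectation starts from compound 1 at 62.5% and no firm direction can be drawn from the data. The expected step of a number 2.5 percentage points lower from compound 1 to compound 3 (within the scatter) is small and stays within the scatter. In this assay the estimated value for compound 3 is 60% with an expected range from 45% to 75% at this single concentration.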

Compound 3, percent growth inhibition at one concentration: 61.7%
Estimate against measurement, compound 3: 1.7 percentage points below, within the range that was stated.
By their numbers in this assay, from the lowest: compound 2; then compounds 3 and 1 (each within the scatter of the next).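

In this assay, going by these compounds alone, the first direct step, a number 0.8 percentage points lower from compound 1 to compound 3 (within the scatter), shows that compound 1 and compound 3 read alike with either cyano or bromo on this aromatic carbon, para to a large group. The triple bond and the hydrogen-bond acceptor counted for cyano are absent from bromo, yet this pair gives no sign in this read-out that either feature is required at this position, at the single concentration tested. Nothing available explains why the two compounds read alike.

The compounds shown cover only these two substituents at this position, so it remains open whether the same holds for an amine, a carboxylic acid or a longer chain such as n-butyl. Also open, going by these compounds, is whether compound 1 and compound 3 would still read alike at other concentrations, since a single-concentration percentage gives no full concentration-response curve for either compound.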